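Swapping amino for chloro on a potent amide

The source may hold more compounds than are shown below. What is called first, only, known or untested is meant among the compounds shown, and "the series" means these compounds.

In a functional assay on MGC-803 cells (Homo sapiens) for inhibition, read by MTT assay, with a stated time of 48 h (on this read-out higher numbers stand for weaker inhibition and lower numbers for stronger inhibition), compound 1 (`COc1ccc(CNc2cc(OC)c(OC)c(OC)c2)cc1[N+](=O)[O-]`) gives 19400 nM while compound 2 (`C/C=C/C(=O)N(Cc1ccc(OC)c(N)c1)c1cc(OC)c(OC)c(OC)c1`) gives 150 nM as the lower of the two numbers, a gap beyond the scatter. Compound 3 (`C/C=C/C(=O)N(Cc1ccc(OC)c(Cl)c1)c1cc(OC)c(OC)c(OC)c1`) has not yet been measured. It carries chloro in place of amino on an aromatic carbon, ortho to a methoxy group (chloro in place of amino on an aromatic carbon). For the measured compounds named here, no measured pair shows this change alone, so the forecast remains uncertain. The expected step in this assay is a weakening beyond the scatter, with an estimated size (a 5.3-fold higher number from compound 2 to compound 3 (0.73 log units; beyond the scatter)). Compound 3 is expected to read 800 nM (range 150 nM to 4000 nM).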

Compound 3, half-maximal inhibitory concentration: 7100 nM
Beside the measured number, compound 3's estimate is 8.9-fold (0.95 log units) below it; the measured number lies above the stated range.
By their numbers in this assay, from the lowest: compound 2; then compound 3; then compound 1.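

In this assay, for the compounds shown here, going from 3-amino-4-methoxyphenyl to 3-chloro-4-methoxyphenyl gives a 47-fold higher number from compound 2 to compound 3 (1.68 log units; beyond the scatter) as the first step with a single change. This aromatic carbon, ortho to a methoxy group, is therefore sensitive to its substituent, and with the rest of the amide unchanged, amino reads far stronger than chloro. Nothing available explains this step.

From the compounds shown here alone, whether amino is unusually favourable here or chloro unusually poor remains open. Hydroxyl, fluoro or methylamino on this carbon could help to separate those two readings.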